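This account rests on a few compounds, and the source may have more. Where it says the series, first, only, none or still open, it means among the compounds named here.

Three indolinone compounds were tested in a functional assay on cells (Leukemia cell, Homo sapiens) for cytotoxicity, with a stated time of 48 h; on this read-out higher numbers stand for weaker inhibition of growth and lower numbers for stronger inhibition of growth. Compound 1 `COc1c(/C=C2/C(=O)Nc3ccccc32)c2ccccc2n1-c1ccccc1` gives 2630 nM in this assay. Compound 3 `COc1c(/C=C2/C(=O)Nc3ccc(Cl)cc32)c2ccccc2n1-c1ccccc1` carries one change relative to compound 1: chloro in place of hydrogen on an aromatic carbon. In this assay compound 3 gives 8910 nM. That change gave a 3.4-fold higher number from compound 1 to compound 3 (0.53 log units; beyond the scatter), so the number rose and growth inhibition weakened by a modest amount.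

Compound 2 `O=C1Nc2ccccc2/C1=C\c1c(Cl)n(CCCc2ccccc2)c2ccccc12` has a different core, and the difference between the two cores is not broken down here. In this assay compound 2 gives 50100 nM, the highest of the three numbers, and it lies beyond the usual scatter from both compound 3 and compound 1.

Compound 4 `O=C1Nc2ccc(Cl)cc2/C1=C\c1c(Cl)n(CCCc2ccccc2)c2ccccc12` has not yet been measured. It differs from compound 2 by chloro in place of hydrogen on an aromatic carbon. The place of this substitution is described in the same words as the place of the change from compound 1 to compound 3, so it is the same change, made on a different core.

Going by the values given here, the only guide is the single earlier example. Since the change from compound 1 to compound 3 weakened growth inhibition, and since compound 2 already starts at a high number, the expectation for compound 4 is a further weakening of about the same size, giving an estimated step of a 3.0-fold higher number from compound 2 to compound 4 (0.48 log units; beyond the scatter). The expected value for compound 4 is therefore 150000 nM, with a likely range from 60000 nM to 400000 nM, and there is a real chance that the assay reports only a limit for compound 4 rather than a number.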

Compound 4, concentration for total growth inhibition: 81300 nM
Compound 4: the middle estimate sits 1.8-fold (0.27 log units) above what was measured; the range from low to high includes it.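

In this assay, putting chloro in place of hydrogen on the core of compound 2 gave a 1.6-fold higher number from compound 2 to compound 4 (0.21 log units; within the scatter), so on this core the effect of the change cannot be told apart from the ordinary variation between repeated measurements. Set beside the same change on the core of compound 1, the two steps do not differ by more than such variation allows: the same change on two cores in this assay, a 3.4-fold higher number (0.53 log units; beyond the scatter) from compound 1 to compound 3 and a 1.6-fold higher number (0.21 log units; within the scatter) from compound 2 to compound 4, 2.1-fold (0.32 log units) apart, within the scatter of two such steps. Going by these compounds alone, this means the results are consistent with the change carrying over from one core to the other at a similar size, but they do not prove it, since only one of the two steps is beyond the scatter and a single pair of cores cannot show that the effect is the same on both, or how it would behave on any other core.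

The compounds shown compare only hydrogen and chloro at this place on the aromatic ring, which leaves open how a fluoro, a methoxy or an amine there would read in this assay. They also leave open whether a carboxylic acid at this place would follow the same course on both cores.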